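The source may report more compounds than this note shows. Statements on the series, on what has been measured and on what is new or still open speak of the compounds shown alone.

Compound 1, `C[C@H](Oc1cccc(F)c1F)C(=O)Nc1ccc2oc(-c3ccc(F)cc3)nc2c1`, was examined in an assay on isolated protein for inhibition of GMP reductase 2 (Homo sapiens), read by spectrophotometry; a higher number here means a weaker inhibitor, a lower number a stronger inhibitor. In this assay compound 1 gives only a limit, > 5000 nM. Compound 2, `COc1ccc(Cc2nc3cc(NC(=O)[C@H](C)Oc4cccc(Cl)c4Cl)ccc3o2)cc1`, also gives only a limit in this assay, > 5000 nM. Compound 3, `C[C@H](Oc1cccc(Cl)c1Cl)C(=O)Nc1ccc2oc(-c3ccc(F)cc3)nc2c1`, likewise gives only a limit in this assay, > 5000 nM. The two measured steps therefore cannot be read: a step that the two limits leave unreadable from compound 1 to compound 3 and a step that the two limits leave unreadable from compound 2 to compound 3. All three values sit at the same place, (the limit of > 5000 nM in this assay, at which 3 of the 3 values shown sit).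

Compound 4, `C[C@H](Oc1cccc(F)c1F)C(=O)Nc1ccc2oc(-c3ccc(O)cc3)nc2c1`, differs from compound 1 by hydroxy in place of fluoro on an aromatic carbon. Neither measured step touches this position, and both are unreadable, so no size and no direction can be taken from them for this assay. Among the compounds with values here, the only footing is that compound 1 gives > 5000 nM, a limit. On that footing compound 4 is expected to give about 8000 nM in this assay, with a range from 2000 nM to 30000 nM, and most probably again only a limit. The expected step is a step that the limit leaves unreadable from compound 1 to compound 4, that is, none that can be called beyond the scatter.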

Compound 4, inhibition constant: > 5000 nM
Compound 4 was reported as a limit; the forecaster's own chance of this, stated with the estimate: 75%; the middle value lies beyond the limit too.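

Compound 4, like compound 1, is reported only as a limit, so the step between them cannot be read: the limit of > 5000 nM in this assay, at which 4 of the 4 values shown sit.

The compounds shown leave open which change, if any, would bring a value inside that limit in this assay.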